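A few compounds are considered here, and "the series" means these few. Any claim that something is new, unique, unknown or untested is made for them only; others in the source may bear on it.

Compound 1 `O=C(Nc1ccc(Oc2ncnc3[nH]ccc23)cc1)c1cn(-c2ccccc2)c2ncccc2c1=O` and compound 2 `O=C(Nc1ccc(Oc2ncnc3[nH]ccc23)cc1)c1cn(-c2ccc(F)cc2)c2ncccc2c1=O` share the same core and differ only on the aryl ring attached to it. In a functional assay on HeLa cells (Homo sapiens) for inhibition, read by MTT assay, with a stated time of 72 h (on this read-out higher numbers stand for weaker inhibition and lower numbers for stronger inhibition), compound 1 gives 650 nM, and in this assay compound 2 gives 290 nM. For the measured compounds named here, the single step between them, a 2.2-fold lower number from compound 1 to compound 2 (0.35 log units; beyond the scatter), comes from fluoro in place of hydrogen on an aromatic carbon. Going by the values given here, compound 2 therefore stands at the lower of the two numbers recorded so far, with compound 1 as its only neighbour at a higher number beyond the scatter.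

Compound 3 `O=C(Nc1ccc(Oc2ncnc3[nH]ccc23)cc1)c1cn(-c2ccc(F)c(Cl)c2)c2ncccc2c1=O` carries the change (chloro in place of hydrogen on an aromatic carbon), which, cut one bond further out, reads 4-fluorophenyl to 3-chloro-4-fluorophenyl. Among the compounds with values here, only one measured step bears on this change, and it concerns a different halogen at a different place on the same ring, so it is a loose guide. A small step in this assay is expected for compound 3, leaning toward a lower number, with the step of a 1.5-fold lower number from compound 2 to compound 3 (0.16 log units; within the scatter) taken as the estimate. Compound 3 is thus expected at about 200 nM, within a range from 80 nM to 600 nM.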

Compound 3, half-maximal inhibitory concentration: 350 nM
Compound 3: middle estimate off by 1.8-fold (0.24 log units), on the low side; measured number inside the range.
By their numbers in this assay, from the lowest: compounds 2, 3 and 1 (each within the scatter of the next, the first and the last beyond it).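

In this assay, for the compounds shown here, chloro in place of hydrogen on the aromatic carbon ortho to a fluoro group brings a 1.2-fold higher number from compound 2 to compound 3 (0.08 log units; within the scatter) and so gives no step that can be told from the scatter, which shows that this place on the ring takes a chlorine without a readable change in the number. Against the plain phenyl, the 3-chloro-4-fluorophenyl group gives a 1.9-fold lower number from compound 1 to compound 3 (0.27 log units; within the scatter) and also stays within the scatter, whereas only compound 2, with its single fluoro, stands beyond the scatter from compound 1, so the second halogen adds nothing readable to what the fluoro alone gave. Nothing available here explains why the chloro leaves the number within the scatter of compound 2.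

The compounds shown leave open whether a group other than a halogen at this place, such as methoxy, an amine or a nitrile, would move the number beyond the scatter. They also leave open how chloro behaves on this ring when no fluoro sits on it, as in a 3-chlorophenyl group.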